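Moving the carboxylate and dropping the chlorine on the aryl ether

The compounds below may be only part of what the source reports. "The series", "measured", "known", "first", "only" and "open" are said of these compounds alone.

Three compounds share a phenyl ketone core joined through a four-carbon chain to a second, acid-bearing aromatic ring. Compound 1 `Cc1c(OCCCCOc2ccccc2C(=O)O)ccc(C(=O)CC2CCCC2)c1C` carries the acid on a ring bearing no halogen, and in an assay on HEK293 cells for positive allosteric modulation of metabotropic glutamate receptor 3 (Rattus norvegicus), read by thallium flux, with a stated time of 2.5 min (on this read-out lower numbers stand for an effect already at smaller amounts and higher numbers for an effect only at larger amounts of compound), compound 1 gives "not determined" (no result reported). Compound 3 `Cc1c(OCCCCOc2ccccc2C(=O)O)ccc(C(=O)CC2CCCC2)c1O` likewise carries the acid on a ring bearing no halogen, and in this assay compound 3 gives "not determined" (no result reported). For the measured compounds named here, compound 2 `Cc1c(OCCCCOc2ccc(C(=O)O)c(Cl)c2)ccc(C(=O)CC(C)C)c1O` is therefore the only member with a number: in this assay compound 2 gives 2050 nM, and with nothing else measured it stands alone, neither strongest nor weakest by comparison.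

Compound 4 `Cc1c(OCCCCOc2cccc(C(=O)O)c2)ccc(C(=O)CC(C)C)c1O` has not yet been measured. It differs from compound 2 in a single place: 3-carboxyphenyl in place of 4-carboxy-3-chlorophenyl on an oxygen on a saturated carbon. Going by the values given here, no step between two measured compounds is available to calibrate such a change, so the expectation rests on compound 2 and the nature of the difference.

With only one anchor, the author expects the step from compound 2 to compound 4 to be small, likely a loss in this assay of a 1.6-fold higher number from compound 2 to compound 4 (0.19 log units; within the scatter), but one that could easily fall within the scatter. For compound 4 the estimate in this assay is 3200 nM, with a plausible range from 900 nM to 11000 nM.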

Compound 4, half-maximal effective concentration: 1430 nM
For compound 4 the middle estimate is 2.2-fold (0.35 log units) above the measured one; the range from low to high includes it.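

In this assay, for the compounds shown here, replacing 4-carboxy-3-chlorophenyl with 3-carboxyphenyl on an oxygen on a saturated carbon gives a 1.4-fold lower number from compound 2 to compound 4 (0.16 log units; within the scatter), the first step that can be read. Compound 2 and compound 4 therefore cannot be told apart in this assay, and at this position the ring can lose its chlorine and carry its carboxylic acid at a different place without a change beyond the usual scatter. No data shown here offer an explanation for this result.

Since both features differ in this single step, the compounds shown do not separate any contribution of the chlorine from that of the acid's placement, and a 4-carboxyphenyl group or a 3-carboxyphenyl group bearing chlorine would be needed to do so. From the compounds shown here alone, it also remains open how this position would respond to a tetrazole in place of the carboxylic acid, or to an amide or a fluorine on the same ring.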